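The source may report more compounds than this note shows. Statements on the series, on what has been measured and on what is new or still open speak of the compounds shown alone.

Measured so far in an assay on HEK293 cells for agonist activity at transient receptor potential cation channel subfamily M member 8 (Homo sapiens), read by fluorescence and calcium flux, with a stated time of 15 min; a lower number here means that less compound is needed, a higher number that more compound is needed for the effect:
compound 1, `CCN(Cc1ccoc1)C(=O)COc1ccc(C)cc1`: 136 nM
compound 2, `CCc1ccc(OCC(=O)N(CC)Cc2cccs2)cc1`: 67 nM
compound 3, `Cc1ccc(OCC(=O)N(Cc2cccs2)c2ccnn2C)cc1`: 422 nM

Compound 3 gives the highest number of the three in this assay. The nearest is compound 1, whose value is lower by more than the scatter; compound 2 lies further off, lower still and also beyond the scatter. All three share the same aryloxyacetamide arrangement, and compound 3 differs from the other two in carrying an aromatic ring directly on the amide-type nitrogen where compounds 1 and 2 carry ethyl.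

Compound 4, `CCCN(Cc1cccs1)C(=O)COc1ccc(C)cc1`, has not yet been measured in this assay. Relative to compound 3 the change is propyl in place of 1-methyl-1H-pyrazol-5-yl on an amide-type nitrogen. This moves compound 4 toward the pattern of compounds 1 and 2, which both show lower numbers than compound 3. A downward step beyond the scatter is therefore expected, a 4.2-fold lower number from compound 3 to compound 4 (0.63 log units; beyond the scatter), on the basis of compound 1 at 136 nM and compound 2 at 67 nM. Compound 4 is estimated at 100 nM, with a range from 40 nM to 260 nM.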

Compound 4, half-maximal effective concentration: 40 nM
Beside the measured number, compound 4's estimate is 2.5-fold (0.40 log units) above it; low and high end bracket the measured number.
By their numbers in this assay, from the lowest: compounds 4 and 2 (each within the scatter of the next); then compound 1; then compound 3.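

Propyl in place of 1-methyl-1H-pyrazol-5-yl on the amide-type nitrogen gives an 11-fold lower number from compound 3 to compound 4 (1.02 log units; beyond the scatter) in this assay and is the first change in the series that can be read at a single place. The two compounds differ only in this nitrogen substituent. Compound 4 carries a saturated chain where compound 3 carries a five-membered aromatic ring and its hydrogen-bond acceptors. Nothing at hand indicates which part of this exchange accounts for the step.

Open, from the compounds shown here alone, is whether a phenyl ring, a longer chain such as butyl, or a propyl chain ending in an amine on this nitrogen would stay near the number of compound 4. Also open is how ethyl and propyl compare here, as the compounds shown that carry them differ elsewhere too.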